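Difluoro to dimethyl on the cyclohexyl amine

This account rests on a few compounds, and the source may have more. Where it says the series, first, only, none or still open, it means among the compounds named here.

Compound 1 `c1ccc(CN(CCCCN(C[C@H]2Cc3ccccc3CN2)[C@H]2CCCc3cccnc32)Cc2ccccc2)cc1` in a functional assay on cells for antagonist activity at C-X-C chemokine receptor type 4 (Homo sapiens), read by fluorescence and calcium flux, with stated times of 25 min and 90 s (a lower number here means a stronger inhibitor, a higher number a weaker inhibitor), gives only a limit, > 16700 nM, which is the limit of the assay rather than a number (the limit of > 16700 nM in this assay, at which 1 of the 3 values shown sits). Compound 2 `c1ccc2c(c1)CN[C@@H](CN(CCCCNC1CCOCC1)[C@H]1CCCc3cccnc31)C2` gives 29.4 nM in this assay. Compound 3 `FC1(F)CCC(NC/C=C/CN(C[C@H]2Cc3ccccc3CN2)[C@H]2CCCc3cccnc32)CC1` gives 82.1 nM in this assay and so stands highest of the two numbers recorded; its nearest neighbour is compound 2, and the gap between them lies beyond the usual scatter. Compound 4 `CC1(C)CCC(NC/C=C/CN(C[C@H]2Cc3ccccc3CN2)[C@H]2CCCc3cccnc32)CC1` has not yet been measured. It differs from compound 3 only in that (4,4-dimethylcyclohexyl in place of 4,4-difluorocyclohexyl on an amine nitrogen), that is, 4,4-dimethylcyclohexyl in place of 4,4-difluorocyclohexyl on an amine nitrogen. Within the data shown here, no pair of measured compounds in this set differs in the same way, so there is no measured step to lean on. The change keeps the ring size and the count of heavy atoms, donors and acceptors, so the step from compound 3 to compound 4 is expected to be small, a 1.0-fold higher number from compound 3 to compound 4 (0.02 log units; within the scatter), and not clearly beyond the scatter in either direction. Compound 4 is therefore expected to give about 85 nM in this assay, within a range from 30 nM to 260 nM.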

Compound 4, half-maximal inhibitory concentration in the C-X-C chemokine receptor type 4 assay: 64.6 nM
Beside the measured number, compound 4's estimate is 1.3-fold (0.12 log units) above it; low and high end bracket the measured number.
By their numbers in the C-X-C chemokine receptor type 4 assay, from the lowest: compound 2; then compounds 4 and 3 (each within the scatter of the next). At a limit, above all of these: compound 1.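

In the C-X-C chemokine receptor type 4 assay compound 4 gives 64.6 nM, and the change on the amine nitrogen gives a 1.3-fold lower number from compound 3 to compound 4 (0.10 log units; within the scatter), so 4,4-dimethylcyclohexyl and 4,4-difluorocyclohexyl cannot be told apart at this position. Among these compounds, this is the first step that isolates a single place, which compounds 1, 2 and 3 could not do among themselves. The data shown offer no measured explanation for this result.

As far as these compounds go, it remains open whether a piperidine or another nitrogen-containing ring in place of 4,4-dimethylcyclohexyl on an amine nitrogen would also stay within the scatter in the C-X-C chemokine receptor type 4 assay. From the compounds shown here alone, in a physicochemical assay for permeability, using PAMPA, with a stated time of 4 h, at pH 7.4, tested at 100 uM (on this read-out higher numbers stand for higher permeability and lower numbers for lower permeability), compound 3 gives 49 nm/s, but compound 4 is recorded as "not determined" (no result reported), so the step to compound 4 cannot be read, and any effect of this change on that read-out remains unknown.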